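Aryl ether series: five-membered ring swaps and maximal response

The compounds below may be only part of what the source reports. "The series", "measured", "known", "first", "only" and "open" are said of these compounds alone.

Measured so far, in a functional assay with Alpha-1A adrenergic receptor (Homo sapiens) as the target, read by calcium flux; a lower number here means a smaller maximal response, a higher number a larger maximal response:
compound 1 `c1cncc(-c2ccccc2OCC2=NCCN2)c1` gives 109%
compound 2 `c1coc(-c2ccccc2OCC2=NCCN2)c1` gives 106%
compound 3 `c1ccc(-c2cc[nH]n2)c(OCC2=NCCN2)c1` gives 119%

All three share the same core and differ only in the five-membered ring on the aromatic carbon. Compound 2 stands lowest of the three numbers, though the gap to the nearest is small: a number 3 percentage points lower from compound 1 to compound 2 (within the scatter). The gap to the furthest is larger: a number 13 percentage points higher from compound 2 to compound 3 (beyond the scatter).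

Compound 4 `Cc1cnsc1-c1ccccc1OCC1=NCCN1` is not yet measured in this assay. It departs from compound 2 at the same position as the steps above: 4-methyl-1,2-thiazol-5-yl in place of furan-2-yl on an aromatic carbon. The two measured steps at this position bear on it directly. One, a number 3 percentage points lower from compound 1 to compound 2 (within the scatter), did not move the maximal response beyond the scatter; the other, a number 13 percentage points higher from compound 2 to compound 3 (beyond the scatter), moved it modestly upward. For the measured compounds named here, neither gives reason to expect a large step from a further ring swap here; a change from nothing to modest, in either direction, is what the series so far supports.

The step expected is therefore a number 4 percentage points higher from compound 2 to compound 4 (within the scatter). For compound 4 the estimate in this assay is 110%, with a range from 98% to 122%.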

Compound 4, largest response reached (reported as maximum), in percent of the reference or control that the assay uses: 104%
Compound 4: middle estimate off by 6 percentage points, on the high side, within the range that was stated.
By their numbers in this assay, from the lowest: compounds 4, 2, 1 and 3 (each within the scatter of the next, the first and the last beyond it).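

Notes on the aryl ether series: in this assay the larger 4-methyl-1,2-thiazol-5-yl, with its second ring hetero atom and added methyl, gives a number 2 percentage points lower from compound 2 to compound 4 (within the scatter) against furan-2-yl and a number 5 percentage points lower from compound 1 to compound 4 (within the scatter) against pyridin-3-yl, so this position accepts a ring carrying sulfur and a methyl group without a change beyond the scatter relative to either of those two groups. The same new compound widens the largest gap seen at this position, with a number 15 percentage points lower from compound 3 to compound 4 (beyond the scatter) in the swap from 1H-pyrazol-3-yl, yet that gap stays modest and 1H-pyrazol-3-yl is set apart only from the furan-2-yl and thiazole compounds, not from the pyridin-3-yl compound. Nothing at hand gives a measured reason for these small differences between the rings.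

From the compounds shown here alone, all four compounds carry an aromatic ring at this carbon, so it remains open whether a saturated group such as morpholin-4-yl, a primary amine or a carboxylic acid would hold the maximal response in the same band. The compounds also leave open whether a longer chain in place of the ring, or a substituent elsewhere on the shared core, would shift it further.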